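Adding a Methyl Where the Toxicity Read-out Hits Its Limit

This account rests on a few compounds, and the source may have more. Where it says the series, first, only, none or still open, it means among the compounds named here.

Measured compounds:
Compound 1, `CCCCSc1nc(C(C)c2c(F)cccc2Cl)c(C)c(=O)[nH]1`, reaches only the assay limit > 1500 nM in an ADME assay on MT4 cells (Homo sapiens) for activation, read by MTT assay; on this read-out lower numbers stand for higher toxicity in this test and higher numbers for lower toxicity in this test.
Compound 2, `CCCCSc1nc(C(CC)c2c(F)cccc2Cl)c(C)c(=O)[nH]1`, reaches only the assay limit > 3000 nM in this assay.
Compound 3, `CCCSc1nc(C(C)c2c(F)cccc2F)c(CC)c(=O)[nH]1`, reaches only the assay limit > 3000 nM in this assay.

None of the three numbers is a measured value; each is a limit of this assay. Compound 1 sits at the limit of > 1500 nM in this assay, at which 1 of the 3 values shown sits. Compound 2 sits at the limit of > 3000 nM in this assay, at which 2 of the 3 values shown sit. Compound 3 sits at the same limit.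

From compound 1 to compound 2 the change is methyl in place of hydrogen on a saturated chain carbon, two bonds along the chain from two aromatic carbons. Because both values are limits, this gives a step that the two limits leave unreadable from compound 1 to compound 2. Compound 3 differs from compound 1 in more than one place, and the difference between the two cores is not broken down here.

The unmeasured compound 4, `CCc1c(C(C)c2c(F)cccc2F)nc(SC(C)CC)[nH]c1=O`, comes from compound 3 by methyl in place of hydrogen on a saturated chain carbon bound to a saturated chain carbon and a sulfur. Among the compounds with values here, this is the same kind of change as the one from compound 1 to compound 2, but not the same change: there the methyl entered on a saturated chain carbon, two bonds along the chain from two aromatic carbons, whereas here it enters on a saturated chain carbon bound to a saturated chain carbon and a sulfur.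

Compound 3 gives only the limit > 3000 nM in this assay. Compound 4 is therefore expected to reach a limit as well, and the expected step is a step that the limit leaves unreadable from compound 3 to compound 4. For compound 4 the estimate is 5000 nM, with a range from 2500 nM to 20000 nM.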

Compound 4, half-maximal cytotoxic concentration: > 3000 nM
Compound 4 gave a limit, no number (the forecaster's own chance of this, stated with the estimate: 85%); the middle value does not contradict the limit.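

Compound 3 and compound 4 both reach only a limit in this assay, and the step between them cannot be read, just as the earlier step from compound 1 to compound 2 cannot. The compounds shown leave open where any of them would give an actual toxicity value and whether going from propylsulfanyl to (sec-butyl)sulfanyl changes that value at all.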